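The source may report more compounds than this note shows. Statements on the series, on what has been measured and on what is new or still open speak of the compounds shown alone.

Working notes on the series. Two compounds have numbers in a functional assay on A549 cells (Homo sapiens) for inhibition, read by MTT assay, with a stated time of 72 h (on this read-out higher numbers stand for weaker inhibition and lower numbers for stronger inhibition), so far. Compound 1 `CNC(=O)c1cc(Oc2ccc(Nc3nccc(N4CCCC4)n3)cc2)ccn1` carries a 2-(methylcarbamoyl)pyridin-4-yl group on the ether oxygen together with a pyrrolidine on the pyrimidine; in this assay compound 1 gives 3410 nM. Compound 2 `c1ccc2c(c1)CCN(c1ccnc(Nc3ccc(Oc4ncnc5ccsc45)cc3)n1)C2` instead pairs a bicyclic thiophene-fused ether group with a tetrahydroisoquinoline; in this assay compound 2 gives 17000 nM, the higher of the two numbers, with the gap to compound 1 lying beyond the usual scatter.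

Compound 3 `CNC(=O)c1cc(Oc2ccc(Nc3nccc(N4CCc5ccccc5C4)n3)cc2)ccn1` is not yet measured. Relative to compound 2 the change is a group of 10 heavy atoms (7 carbon, 2 nitrogen, 1 oxygen; one six-membered aromatic ring with 1 hetero atom) in place of a group of 9 heavy atoms (6 carbon, 2 nitrogen, 1 sulfur; one five-membered aromatic ring with 1 hetero atom, one six-membered aromatic ring with 2 hetero atoms), on an oxygen on an aromatic ring. Compound 3 therefore shares its ether group with compound 1 and its amine with compound 2. Among the measured compounds shown here, no step with a single change is available. For the measured compounds named here, since the only compound bearing the same ether group, compound 1, gives 3410 nM, a move towards stronger inhibition beyond the scatter is expected for the step of a 2.8-fold lower number from compound 2 to compound 3 (0.45 log units; beyond the scatter), with wide uncertainty since the amine also differs between compound 1 and compound 2. Compound 3 is estimated at 6000 nM, within a range of 2000 nM to 18000 nM.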

Compound 3, half-maximal inhibitory concentration: 3190 nM
The estimate for compound 3 lay 1.9-fold (0.27 log units) above the measured number; low and high end bracket the measured number.
By their numbers in this assay, from the lowest: compounds 3 and 1 (each within the scatter of the next); then compound 2.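

Among the compounds shown here, compound 3 gives the first single-place reading at the ether oxygen: in this assay, 2-(methylcarbamoyl)pyridin-4-yl in place of the sulfur-bearing bicyclic group, on an oxygen on an aromatic ring, with 1,2,3,4-tetrahydroisoquinolin-2-yl held fixed, gives a 5.3-fold lower number from compound 2 to compound 3 (0.73 log units; beyond the scatter), so the gap seen earlier between the two differently substituted compounds now has a change at this position behind it. With 2-(methylcarbamoyl)pyridin-4-yl held fixed, 1,2,3,4-tetrahydroisoquinolin-2-yl in place of pyrrolidin-1-yl on an aromatic carbon gives a 1.1-fold lower number from compound 1 to compound 3 (0.03 log units; within the scatter), so in this assay this exchange of amine shows no difference that can be told from the scatter. No measurement at hand speaks to the origin of either step.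

The compounds shown leave open whether the step at the ether oxygen keeps its size with pyrrolidin-1-yl on the aromatic carbon, and which part of 2-(methylcarbamoyl)pyridin-4-yl it depends on, as a primary carboxamide, a methyl ester or a carboxylic acid in place of the methylcarbamoyl group would show. They also leave open whether the amine place stays as flat with a morpholine or a piperazine there.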